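Bis-aziridinyl quinone side chains: carbamate replaced by methoxypropyl

The source may report more compounds than this note shows. Statements on the series, on what has been measured and on what is new or still open speak of the compounds shown alone.

Measured so far:
compound 1, `CCCC1=C(N2CC2)C(=O)C(C(COC(N)=O)OC)=C(N2CC2)C1=O`, 4.64
compound 2, `CC1=C(N2CC2)C(=O)C(CC(C)OC(N)=O)=C(N2CC2)C1=O`, 5.18
compound 3, `CCC1=C(N2CC2)C(=O)C(CCOC(N)=O)=C(N2CC2)C1=O`, 4.88

All three measured compounds share the same core and differ in the side chains on the ring. In a functional assay on L1210 cells (Mus musculus), with a stated time of 1 days (on this read-out higher numbers stand for higher potency (the scale is a negative logarithm) and lower numbers for lower potency), compound 2 gives the highest of the three numbers, at 5.18. Compound 3 stands nearest, with 4.88, a gap within the usual scatter, so no order between compound 2 and compound 3 can be read. Compound 1 stands furthest, at 4.64, a gap beyond the scatter. Among the measured compounds shown here, no pair of measured compounds differs in one place only, so no single-change step is available in this assay.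

Compound 4, `CCC(OC)C1=C(N2CC2)C(=O)C(C)=C(N2CC2)C1=O`, has not been measured. Compared with compound 2 the change is a group of 5 heavy atoms (4 carbon, 1 oxygen; no ring) in place of a group of 7 heavy atoms (4 carbon, 1 nitrogen, 2 oxygen; no ring), on a double-bonded ring carbon. Every measured compound carries a carbamate-bearing side chain; compound 4 carries none, so the series gives no direct guide to this change. The expectation is a moderate step downward in this assay, beyond the scatter, resting on the spread seen between compound 2 and compound 1. Compound 4 is estimated at 4.6, with a range from 4.1 to 5.1, which means an expected step of a number 0.58 log units lower from compound 2 to compound 4 (beyond the scatter).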

Compound 4, logarithm of the reciprocal of the active concentration, log(1/C): 4.84
Estimate against measurement, compound 4: 0.24 log units below; measured number inside the range.
By their numbers in this assay, from the lowest: compounds 1, 4, 3 and 2 (each within the scatter of the next, the first and the last beyond it).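

In this assay, among the compounds shown here, this is the first change that can be read at a single place: on the double-bonded ring carbon, next to the ring atom that bears an aziridin-1-yl group, 1-methoxypropyl replaces the carbamate-bearing side chain, giving a number 0.34 log units lower from compound 2 to compound 4 (beyond the scatter). The step is modest, and compound 4 still gives 4.84 with no carbamate on the molecule, so in this assay a carbamate at this position is not a requirement for a measurable read-out, though its replacement by 1-methoxypropyl does cost some potency. Nothing available here bears on why the number falls with this change.

For the compounds shown here, the single step replaces the whole side chain at once, so the loss of the carbamate cannot be separated from the change in the chain that carries it, and a single replacement gives no trend at this position. From the compounds shown here alone, whether a simple hydroxyl, an amine or a longer alkoxyalkyl chain on the same ring carbon would stand nearer compound 2 or nearer compound 4 remains open.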